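Amide Addition on a Nitrogen-Containing Core: What to Expect

The compounds below may be only part of what the source reports. "The series", "measured", "known", "first", "only" and "open" are said of these compounds alone.

Compound 1 `C[C@H](Oc1ccc(NC(=O)CC(=O)O)c(C2CC2)c1)c1c(Cl)ccc(F)c1Cl`: 1.9
Compound 2 `C[C@H](Oc1cccc(C2CC2)c1)c1c(Cl)ccc(F)c1Cl`: 5
Compound 3 `C[C@H](Oc1cccc(C2CC2)n1)c1c(Cl)ccc(F)c1Cl`: 4.9

All three were measured in a physicochemical assay for lipophilicity, using the shake flask method; on this read-out lower numbers stand for lower lipophilicity and higher numbers for higher lipophilicity. Compound 2 and compound 3 lie within the usual scatter of each other; how their two cores differ is not broken down here. From compound 2 to compound 1 the change is ((carboxymethyl)carbonyl)amino in place of hydrogen on an aromatic carbon, and it made a step of a number 3.10 log units lower from compound 2 to compound 1 (beyond the scatter).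

Compound 4 `C[C@H](Oc1ccc(NC(=O)CC(=O)O)c(C2CC2)n1)c1c(Cl)ccc(F)c1Cl` is reached from compound 3 by ((carboxymethyl)carbonyl)amino in place of hydrogen on an aromatic carbon. This is the same kind of change, not the same one: in compound 4 the ring carrying the new group is a six-membered aromatic ring with 1 nitrogen, and the place is two atoms from the ring nitrogen, whereas in compound 1 the ring is of carbon only. The step from compound 3 to compound 4 is expected to be a number 3.10 log units lower from compound 3 to compound 4 (beyond the scatter), because of a number 3.10 log units lower from compound 2 to compound 1 (beyond the scatter) on compound 2. Compound 4 is therefore estimated at 1.8, expected between 1.3 and 2.4.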

Compound 4, distribution coefficient: 1.4
Beside the measured number, compound 4's estimate is 0.40 log units above it, within the range that was stated.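

In this assay the change to ((carboxymethyl)carbonyl)amino in place of hydrogen on an aromatic carbon gave a step of a number 3.50 log units lower from compound 3 to compound 4 (beyond the scatter) on a ring with 1 nitrogen, and a step of a number 3.10 log units lower from compound 2 to compound 1 (beyond the scatter) on a ring of carbon only. The change therefore carried over from one core to the other in direction, and both steps are large, but two pairs cannot show that this holds on further cores or that the ring nitrogen has any bearing on the size of the step. Nothing measured here explains the result.

The compounds shown leave open how a simple amine at the same place would behave on these two cores. They also leave open whether a longer chain ending in a carboxylic acid would give steps like these.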